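Chloro to prop-1-yn-1-yl: clearance notes on compound 3

A few compounds are considered here, and "the series" means these few. Any claim that something is new, unique, unknown or untested is made for them only; others in the source may bear on it.

Among the measured compounds shown here, in an ADME assay (liver) for metabolic stability, with Liver microsome (Rattus norvegicus) as the target, using microsomes and NADPH, with a stated time of 30 min, at 37 degrees C, tested at 1 uM (on this read-out lower numbers stand for slow clearance and higher numbers for fast clearance), compound 2 (`Nc1ccc(S(=O)(=O)c2ccc(-c3ncc(C(O)(C(F)(F)F)C(F)(F)F)cc3Cl)cc2)cn1`) gives 18 mL.min-1.g-1 and holds the only actual number in this small set. Compound 1 (`CC(O)(c1ccc(-c2ccc(S(=O)(=O)c3ccc(N)nc3)cn2)nc1)C(F)(F)F`) gives < 14 mL.min-1.g-1 as a limit of the assay, not a number. For the measured compounds named here, no single-place step connects these two compounds, so the series offers no measured guide to the size of a substitution.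

Compound 3 (`CC#Cc1cc(C(O)(C(F)(F)F)C(F)(F)F)cnc1-c1ccc(S(=O)(=O)c2ccc(N)nc2)cc1`) carries prop-1-yn-1-yl in place of chloro on an aromatic carbon is the whole difference from compound 2.

The expectation therefore starts from compound 2 at 18 mL.min-1.g-1 and allows only a small rise in this assay, within the usual scatter. The expected change is a 1.3-fold higher number from compound 2 to compound 3 (0.12 log units; within the scatter) on this estimate. Compound 3 is estimated at 24 mL.min-1.g-1 with 12 mL.min-1.g-1 to 50 mL.min-1.g-1 as the expected range.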

Compound 3, intrinsic clearance in microsomes: 177 mL.min-1.g-1
Compound 3: middle estimate off by 7.4-fold (0.87 log units), on the low side; the whole stated range lies below it.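

In this assay, the position on the aromatic carbon two atoms from the ring nitrogen and ortho to a large group proves sensitive to substitution: prop-1-yn-1-yl in place of chloro gives a 9.8-fold higher number from compound 2 to compound 3 (0.99 log units; beyond the scatter). Among the compounds shown here, this is the only single-place step in the set, so it provides the first measured size for a change, and that size lies well beyond the scatter. Nothing shown here bears on why the step is so large.

From the compounds shown here alone, it remains open whether the rise depends on the triple bond itself or simply on replacing chloro with a larger carbon group, a question that a nitrile, an ethyl or a cyclopropyl group at the same position could address. Going by these compounds, it is also open whether prop-1-yn-1-yl would have a similar effect on the core of compound 1.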